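This account rests on a few compounds, and the source may have more. Where it says the series, first, only, none or still open, it means among the compounds named here.

Compound 1 `Cc1cc(C)cc(COc2ccc(-c3cc(CN4CCN(Cc5ccc(C(F)(F)F)cc5)CC4)no3)cc2)c1`: 6000 nM in a functional assay on Mahlavu cells (Homo sapiens) for antiproliferative activity, read by sulforhodamine B assay, with a stated time of 72 h; on this read-out lower numbers stand for stronger inhibition and higher numbers for weaker inhibition
Compound 2 `FC(F)(F)c1ccc(CN2CCN(Cc3cc(-c4ccc(OCc5ccc(Cl)cc5)cc4)on3)CC2)cc1`: 3700 nM in this assay
Compound 3 `N#Cc1ccc(COc2ccc(-c3cc(CN4CCN(Cc5ccc(C(F)(F)F)cc5)CC4)no3)cc2)cc1`: 4300 nM in this assay

On these numbers compound 3 sits between the other two, yet all three lie within the usual scatter of one another: the gap a 1.2-fold higher number from compound 2 to compound 3 (0.07 log units; within the scatter) is small, and so is a 1.4-fold lower number from compound 1 to compound 3 (0.14 log units; within the scatter).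

Compound 4 `COc1cc(COc2ccc(-c3cc(CN4CCN(Cc5ccc(C(F)(F)F)cc5)CC4)no3)cc2)cc(OC)c1` differs from compound 3 by 3,5-dimethoxyphenyl in place of 4-cyanophenyl on a saturated chain carbon bound to an oxygen on an aromatic ring. The same place has already been varied twice, in a 1.6-fold lower number from compound 1 to compound 2 (0.21 log units; within the scatter) and a 1.4-fold lower number from compound 1 to compound 3 (0.14 log units; within the scatter), and neither step left the scatter. The measured steps therefore give no reason to expect a change beyond the scatter in this assay for compound 4, and the step of a 1.2-fold higher number from compound 3 to compound 4 (0.07 log units; within the scatter) is estimated accordingly. Compound 4 is expected to give about 5000 nM, with a range from 2500 nM to 10000 nM.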

Compound 4, half-maximal inhibitory concentration: 4300 nM
Beside the measured number, compound 4's estimate is 1.2-fold (0.07 log units) above it; the range from low to high includes it.
By their numbers in this assay, from the lowest: compounds 2, 3, 4 and 1 (each within the scatter of the next).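

In this assay the place on a saturated chain carbon bound to an oxygen on an aromatic ring also accepts 3,5-dimethoxyphenyl, with no change at the digits printed from compound 3 to compound 4 (within the scatter) and a 1.2-fold higher number from compound 2 to compound 4 (0.07 log units; within the scatter) and a 1.4-fold lower number from compound 1 to compound 4 (0.14 log units; within the scatter). All four groups tried there now lie within the scatter of one another, so even the two oxygen-bearing methoxy groups leave the number unmoved. Nothing measured here explains this flat response. Going by these compounds, whether a carboxylic acid or an amine on this phenyl ring would move the number beyond the scatter remains open. So does the effect of a longer chain at this place.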